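A ring swap among compounds sitting at a limit

A few compounds are considered here, and "the series" means these few. Any claim that something is new, unique, unknown or untested is made for them only; others in the source may bear on it.

Measured in an ADME assay on J774 cells (Mus musculus) for cytotoxicity, read by resazurin assay, with a stated time of 72 h (on this read-out lower numbers stand for higher toxicity in this test and higher numbers for lower toxicity in this test), as follows:
- Compound 1 `C/C(=N\Nc1nc(-c2ccc(C)cc2)cs1)c1ccc(Cl)c(Cl)c1` gives > 50000 nM which is a limit
- Compound 2 `C/C(=N\Nc1nc(-c2ccc(Cl)cc2Cl)cs1)c1ccc(Cl)c(Cl)c1` gives > 50000 nM which is a limit
- Compound 3 `C/C(=N\Nc1nc(-c2ccc(Cl)c(Cl)c2)cs1)c1ccc(Cl)c(Cl)c1` gives > 50000 nM which is a limit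

Compound 3 thus stands with the other two, and the data show the limit of > 50000 nM in this assay, at which 3 of the 3 values shown sit, with no exact number for any of them. Compound 4 `COc1ccc(-c2csc(N/N=C(\C)c3ccc(Cl)c(Cl)c3)n2)cc1` differs from it by 4-methoxyphenyl in place of 3,4-dichlorophenyl on an aromatic carbon on an aromatic carbon next to the ring nitrogen.

Three measured steps change this same group: a step that the two limits leave unreadable from compound 1 to compound 2 and a step that the two limits leave unreadable from compound 1 to compound 3 and also a step that the two limits leave unreadable from compound 2 to compound 3 so none has a size to carry over. No direction of change is expected in this assay because the limit of > 50000 nM in this assay, at which 3 of the 3 values shown sit, applies to all three compounds. The expected step is a number no higher from compound 3 to compound 4 (the limit leaves the size open) and thus none beyond the scatter. For compound 4 the estimate is 50000 nM with an expected range from 20000 nM to 100000 nM and another limit is likely.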

Compound 4, half-maximal cytotoxic concentration: > 50000 nM
Compound 4: only a limit was reported; the forecaster's own chance of this, stated with the estimate: 75%; the middle value sits exactly at the limit.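

Compound 4 gives > 50000 nM as a limit. Among these compounds, no step between compound 4 and compound 1, compound 2 or compound 3 can be read, because all of them sit at one limit: the limit of > 50000 nM in this assay, at which 4 of the 4 values shown sit. Whether any of these ring swaps changes toxicity in this assay at all stays open among the compounds shown.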